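Two methoxy groups in place of two ethoxy groups

A few compounds are considered here, and "the series" means these few. Any claim that something is new, unique, unknown or untested is made for them only; others in the source may bear on it.

Compounds measured so far:
compound 1, `CCOc1cc(CN(C)C(=O)c2c(OCCCC3CCN(C(=O)OC(C)(C)C)CC3)c3ccccc3n(C)c2=O)cc(OCC)c1`, 275 nm/s
compound 2, `CN(Cc1cc(C(F)(F)F)cc(C(F)(F)F)c1)C(=O)c1c(OCCCC2CCN(C(=O)OC(C)(C)C)CC2)c2ccccc2n(C)c1=O`, 11 nm/s
compound 3, `CN(Cc1cc(C(F)(F)F)cc(C(F)(F)F)c1)C(=O)c1c(OCCCC2CCN(C(=O)OC3(C)CC3)CC2)c2cccnc2n(C)c1=O`, 721 nm/s

In an ADME assay for permeability, using PAMPA, at pH 7.4 (a higher number here means that the compound crosses the layer faster, a lower number that the compound crosses the layer more slowly), compound 1 gives 275 nm/s, the second highest of the three numbers. Its nearest neighbour is compound 3, whose value of 721 nm/s lies beyond the scatter above it; compound 2, with 11 nm/s, sits far below it. Compound 4, `COc1cc(CN(C)C(=O)c2c(OCCCC3CCN(C(=O)OC(C)(C)C)CC3)c3ccccc3n(C)c2=O)cc(OC)c1`, has not yet been measured in this assay. It differs from compound 1 in one place: 3,5-dimethoxyphenyl in place of 3,5-diethoxyphenyl on a saturated chain carbon bound to an amide-type nitrogen. The shared core, the chain that carries it and the carbamate on the piperidine are unchanged. Within the data shown here, no measured pair shows this change alone, so the expectation rests on compound 1 alone. The step from compound 1 to compound 4 is expected to be small, at most a slight decrease, and most likely within the scatter: a 1.3-fold lower number from compound 1 to compound 4 (0.10 log units; within the scatter). Compound 4 is therefore estimated at 220 nm/s, with a range from 100 nm/s to 450 nm/s.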

Compound 4, apparent permeability: 295 nm/s
Beside the measured number, compound 4's estimate is 1.3-fold (0.13 log units) below it, and the stated range covers the measured number.
By their numbers in this assay, from the lowest: compound 2; then compounds 1 and 4 (each within the scatter of the next); then compound 3.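

In this assay, 3,5-dimethoxyphenyl in place of 3,5-diethoxyphenyl on a saturated chain carbon bound to an amide-type nitrogen gives a 1.1-fold higher number from compound 1 to compound 4 (0.03 log units; within the scatter). Among these compounds, this is the first comparison that isolates a single change, and it shows that, on the core and carbamate of compound 1, ethoxy and methoxy groups at this position cannot be told apart in this measurement. No measurement shown here bears on the reason for this result.

As far as these compounds go, it remains open whether the same holds for a propoxy or isopropoxy group, or for a hydroxyl group or an amine in place of these alkoxy groups. From the compounds shown here alone, it is also open whether methoxy and ethoxy groups would remain equivalent with a different carbamate on the piperidine.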